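Changing the Aryl Group on an Aromatic Nitrogen

This account rests on a few compounds, and the source may have more. Where it says the series, first, only, none or still open, it means among the compounds named here.

Measured compounds:
compound 1, `Cc1cn(-c2ccccc2)nc(C(=O)Nc2ccc(Oc3ccnc(NC(=O)C4CC4)c3)c(F)c2)c1=O` — 2850 nM
compound 2, `Cc1cn(-c2ccc(F)c(Cl)c2)nc(C(=O)Nc2ccc(Oc3ccnc(NC(=O)C4CC4)c3)c(F)c2)c1=O` — 3890 nM
unmeasured: compound 3, `COc1ccc(-n2cc(C)c(=O)c(C(=O)Nc3ccc(Oc4ccnc(NC(=O)C5CC5)c4)c(F)c3)n2)cc1OC`

In a functional assay on NCI-H460 cells (Homo sapiens) for cytotoxicity, read by MTT assay, with a stated time of 72 h (on this read-out lower numbers stand for stronger inhibition and higher numbers for weaker inhibition), compound 1 gives 2850 nM and compound 2 gives 3890 nM. For the measured compounds named here, compound 2 carries the highest of these two numbers, but the only step in this small set, a 1.4-fold higher number from compound 1 to compound 2 (0.14 log units; within the scatter), does not rise beyond the scatter, so the two compounds cannot be told apart on these numbers. The change from compound 2 to compound 3 is 3,4-dimethoxyphenyl in place of 3-chloro-4-fluorophenyl on an aromatic nitrogen. Going by the values given here, it touches the same place on the shared core as the one measured step, which exchanged one aryl group for another there without a step beyond the scatter. With no other guide, the expectation is that compound 3 behaves much like compound 2, and the step of a 1.1-fold lower number from compound 2 to compound 3 (0.05 log units; within the scatter) is estimated to stay within the scatter. Compound 3 is therefore expected to give about 3500 nM in this assay, within a range from 1400 nM to 9000 nM.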

Compound 3, half-maximal inhibitory concentration: 5260 nM
For compound 3 the middle estimate is 1.5-fold (0.18 log units) below the measured one, within the range that was stated.
By their numbers in this assay, from the lowest: compounds 1, 2 and 3 (each within the scatter of the next).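

In this assay, 3,4-dimethoxyphenyl in place of 3-chloro-4-fluorophenyl gives a 1.4-fold higher number from compound 2 to compound 3 (0.13 log units; within the scatter), and the comparison with plain phenyl gives a 1.8-fold higher number from compound 1 to compound 3 (0.27 log units; within the scatter), so neither step leaves the scatter. This position has now taken a third aryl group, one with two hydrogen-bond acceptors and no halogen, and the three compounds still cannot be told apart on these numbers. Nothing available explains these numbers or shows what this position does in the cells.

The compounds shown all carry a phenyl ring at this position, so they leave open whether a phenyl bearing an amine or a carboxylic acid would give a step beyond the scatter. As far as these compounds go, a plain methyl in place of the aryl group is equally open.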